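Swapping phenoxy for 4-nitrophenyl on a carbonyl carbon

The compounds below may be only part of what the source reports. "The series", "measured", "known", "first", "only" and "open" are said of these compounds alone.

In a functional assay on KB cells (Homo sapiens) for cytotoxicity (on this read-out lower numbers stand for stronger inhibition and higher numbers for weaker inhibition), compound 1 `COc1ccc(S(=O)(=O)N2CCc3cccc(NC(=O)C(C)(C)C)c32)cc1` gives 359 nM and compound 2 `COC(=O)c1ccc(C(=O)Nc2cccc3c2N(S(=O)(=O)c2ccc(OC)cc2)CC3)cc1` gives 376 nM. Compound 3 `COc1ccc(S(=O)(=O)N2CCc3cccc(NC(=O)Oc4ccccc4)c32)cc1` gives > 10000 nM, which is a limit of the assay and not a number. Compound 4 `COc1ccc(S(=O)(=O)N2CCc3cccc(NC(=O)c4ccc([N+](=O)[O-])cc4)c32)cc1` differs from it as follows: 4-nitrophenyl in place of phenoxy on a carbonyl carbon. Putting phenoxy on that carbonyl carbon gave two large steps, an at least 27-fold higher number from compound 1 to compound 3 (1.44 log units; beyond the scatter) and an at least 26-fold higher number from compound 2 to compound 3 (1.42 log units; beyond the scatter). Exchanging the two other groups gave only a 1.0-fold higher number from compound 1 to compound 2 (0.02 log units; within the scatter), within the scatter. Compound 4 loses phenoxy and carries a phenyl group with a substituent, like compound 2 at 376 nM. The expected change is therefore large and towards a lower number, an at least 25-fold lower number from compound 3 to compound 4 (1.39 log units; beyond the scatter). For compound 4, the estimated value is 400 nM, with an expected range of 100 nM to 2500 nM.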

Compound 4, half-maximal inhibitory concentration: 102 nM
The estimate for compound 4 lay 3.9-fold (0.59 log units) above the measured number; low and high end bracket the measured number.
By their numbers in this assay, from the lowest: compound 4; then compounds 1 and 2 (each within the scatter of the next). At a limit, above all of these: compound 3.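

In this assay, the group on this carbonyl carbon can do more than compound 1 and compound 2 showed, since those two sit within the scatter of each other: 4-nitrophenyl gives a 3.5-fold lower number from compound 1 to compound 4 (0.55 log units; beyond the scatter) and a 3.7-fold lower number from compound 2 to compound 4 (0.57 log units; beyond the scatter). Both steps are modest. The largest step is an at least 98-fold lower number from compound 3 to compound 4 (1.99 log units; beyond the scatter), but compound 3 stands at a limit and not at a number: the limit of > 10000 nM in this assay, at which 1 of the 4 values shown sits.

As far as these compounds go, what remains open is whether the nitro group itself matters. An amine or a carboxylic acid on the same aromatic carbon would test this.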